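Changing the Ring on the Carbonyl Carbon

A few compounds are considered here, and "the series" means these few. Any claim that something is new, unique, unknown or untested is made for them only; others in the source may bear on it.

Compound 1 `O=C(NCc1cccc(Cn2cnc3ccccc32)c1)c1cc(Br)c[nH]1`: 16 nM
Compound 2 `Cc1ccc2[nH]c(C(=O)NCc3cccc(Cn4cnc5ccccc54)c3)cc2c1`: 636 nM

Among the compounds with values here, in an assay for inhibition of Indoleamine 2,3-dioxygenase 1 (Homo sapiens), read by HPLC, with a stated time of 48 h (on this read-out higher numbers stand for weaker inhibition and lower numbers for stronger inhibition), compound 2 has the highest number of the two; the only measured step is a 40-fold higher number from compound 1 to compound 2 (1.60 log units; beyond the scatter). Compound 3 `O=C(NCc1cccc(Cn2cnc3ccccc32)c1)c1nc2ccccc2[nH]1` alters the same position: 1H-benzimidazol-2-yl in place of 5-methyl-1H-indol-2-yl on a carbonyl carbon. Within the data shown here, no measured step covers this exact exchange; the one known step only shows that the group on the carbonyl carbon can shift the number a great deal. Compound 3 is therefore expected to stay near compound 2, with an estimated step of a 1.6-fold lower number from compound 2 to compound 3 (0.20 log units; within the scatter). The estimated value for compound 3 is 400 nM, within a range of 80 nM to 2000 nM.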

Compound 3, half-maximal inhibitory concentration: 407 nM
The estimate for compound 3 lay 1.0-fold (0.01 log units) below the measured number; the measured number falls inside the stated range.
By their numbers in this assay, from the lowest: compound 1; then compounds 3 and 2 (each within the scatter of the next).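

In this assay the exchange of 5-methyl-1H-indol-2-yl for 1H-benzimidazol-2-yl gives a 1.6-fold lower number from compound 2 to compound 3 (0.19 log units; within the scatter) and stays within the scatter, so adding a hydrogen-bond acceptor to the entering group leaves these two compounds indistinguishable. Within the data shown here, the new compound also differs clearly from the bromopyrrole, with a 25-fold higher number from compound 1 to compound 3 (1.41 log units; beyond the scatter) as the step, so both fused two-ring groups sit well apart from the single ring of compound 1. No measurement at hand bears on what lies behind these numbers.

Still open, going by these compounds, is whether the low number of compound 1 goes with its bromine or with its single ring. A plain 1H-pyrrol-2-yl group or a 4-chloro-1H-pyrrol-2-yl group on the carbonyl carbon could separate the two.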